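Swapping the Aryl Group: From Compound 3 to Compound 4

This account rests on a few compounds, and the source may have more. Where it says the series, first, only, none or still open, it means among the compounds named here.

The measured compounds so far:

Compound 1, `CS(=O)(=O)c1ccc(Cc2nnc3n2N=C(c2ccc(-c4ccccc4)cc2)CS3)cc1`, gives 67.9%.
Compound 2, `CS(=O)(=O)c1ccc(Cc2nnc3n2N=C(c2cc(Cl)sc2Cl)CS3)cc1`, gives 25.5%.
Compound 3, `CS(=O)(=O)c1ccc(Cc2nnc3n2N=C(c2ccc(Cl)cc2Cl)CS3)cc1`, gives 27.3%.

These numbers come from a functional assay on RAW264.7 cells (Mus musculus) for cytotoxicity, read by MTT assay, with a stated time of 48 h, tested at 50 uM; on this read-out higher numbers stand for a stronger effect at the one concentration tested and lower numbers for a weaker effect. Among the measured compounds shown here, compound 3 stands second highest of the three numbers; its nearest neighbour is compound 2, and the one step measured so far, a number 1.8 percentage points higher from compound 2 to compound 3 (within the scatter), lies within the scatter, so the two cannot be told apart. Compound 1, at the far end, shows a clearly higher number, 67.9%, whereas compound 3 gives 27.3%.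

Compound 4, `Cc1ccc(C2=Nn3c(Cc4ccc(S(C)(=O)=O)cc4)nnc3SC2)cc1`, has not yet been measured. It differs from compound 3 in one place: 4-methylphenyl in place of 2,4-dichlorophenyl on a carbon with a double bond to nitrogen. For the measured compounds named here, the only measured step changes a different kind of group on the same carbon, and it moved the number hardly at all. Going by the values given here, no measured step tells what happens when chlorine atoms are traded for a single methyl group on this ring, so the direction is open. The higher number of compound 1 shows that a plain carbon-only aryl group at this position can go with a strong effect, but one compound is thin evidence. Compound 4 is therefore expected to land between these neighbours, with an estimated step of a number 12.7 percentage points higher from compound 3 to compound 4 (beyond the scatter). The estimate for compound 4 is 40%, with a range from 15% to 65%.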

Compound 4, a percentage reported as activity, at one concentration (the size of the read-out at that concentration, not a potency): 37.9%
Estimate against measurement, compound 4: 2.1 percentage points above, and the stated range covers the measured number.
By their numbers in this assay, from the lowest: compounds 2 and 3 (each within the scatter of the next); then compound 4; then compound 1.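

In this assay, among the compounds shown here, 4-methylphenyl in place of 2,4-dichlorophenyl gives a number 10.6 percentage points higher from compound 3 to compound 4 (beyond the scatter), the first single change on this carbon with a double bond to nitrogen that clearly moves the number, since the earlier swap between the two chlorine-bearing groups stayed within the scatter. Measured against the thiophene-based group, 4-methylphenyl gives a number 12.4 percentage points higher from compound 2 to compound 4 (beyond the scatter), so among the three compounds whose aryl groups are a single ring, the two carrying chlorine both sit below the one carrying methyl. The substituent on the outer ring also counts: methyl in place of phenyl on an aromatic carbon gives a number 30 percentage points lower from compound 1 to compound 4 (beyond the scatter), the largest of the three new steps, which places compound 4 clearly below compound 1 while keeping it above the chlorine-bearing pair.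

Nothing measured here explains why the number moves with these groups. As far as these compounds go, it remains open whether a single chlorine, a methoxy group, an amine or a longer alkyl chain on this phenyl ring would follow the same order, and whether these differences would hold at concentrations other than the one tested.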